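A few compounds are considered here, and "the series" means these few. Any claim that something is new, unique, unknown or untested is made for them only; others in the source may bear on it.

Series notes, amide variation on the shared core.

Compound 1 `O=C(NCc1ccccc1)c1cc(Oc2ccc(/C=C/c3ccccn3)cc2)ccn1` and compound 2 `O=C(Nc1ccccc1)c1cc(Oc2ccc(/C=C/c3ccncc3)cc2)ccn1` have both been tested in a functional assay on A549 cells (Homo sapiens) for antiproliferative activity, read by CCK-8 assay, with a stated time of 48 h; a higher number here means a weaker inhibitor, a lower number a stronger inhibitor. Compound 1 gives 18800 nM in this assay. For the measured compounds named here, compound 2 gives 79700 nM, which is the highest of the two numbers so far; the gap to compound 1 is beyond the scatter, but the two structures differ in more than one place, so the values can only be set side by side.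

Compound 3 `O=C(NC1CC1)c1cc(Oc2ccc(/C=C/c3ccncc3)cc2)ccn1` has not yet been measured in this assay. Relative to compound 2 the difference is cyclopropyl in place of phenyl on an amide-type nitrogen. Going by the values given here, no single-point step of this kind stands among the measured compounds, so nothing here shows how the amide substituent alone moves this assay. The expectation is a small step from compound 2 to compound 3 a 1.6-fold lower number from compound 2 to compound 3 (0.20 log units; within the scatter), at most around the edge of the scatter, towards a somewhat lower number. Compound 3 is therefore estimated at 50000 nM, with a range from 15000 nM to 200000 nM.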

Compound 3, half-maximal inhibitory concentration: 35500 nM
For compound 3 the middle estimate is 1.4-fold (0.15 log units) above the measured one, and the stated range covers the measured number.
By their numbers in this assay, from the lowest: compounds 1 and 3 (each within the scatter of the next); then compound 2.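

In this assay the substituent on the amide-type nitrogen now has its first single-point reading: cyclopropyl in place of phenyl gives a 2.2-fold lower number from compound 2 to compound 3 (0.35 log units; beyond the scatter), a modest step. This position therefore responds to the exchange, with the entering group the smaller one, at 3 heavy atoms against 6, and a three-membered non-aromatic ring replacing a six-membered aromatic one. Which of these differences carries the step cannot be told from one pair, and no measurement at hand accounts for it.

Open, on these data alone, is whether an open-chain isopropyl group, or a dimethylaminoethyl chain carrying an amine, on the same nitrogen would continue in this direction or reverse it. Also open, as far as these compounds go, is whether the same exchange gives a step of similar size on the core of compound 1.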